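Hydroxymethyl to carboxy on the compound 3 scaffold

A few compounds are considered here, and "the series" means these few. Any claim that something is new, unique, unknown or untested is made for them only; others in the source may bear on it.

Compound 3 `Cc1cc(=O)c2c(O)c(CN3CCCC3CO)c(O)c([C@H]3CCN(C)C[C@H]3O)c2o1` stands highest of the three measured compounds in a functional assay on HL-60 cells (Homo sapiens) for inhibition, read by MTT assay, with a stated time of 48 h, tested at 10 uM; on this read-out lower numbers stand for less inhibition of growth and higher numbers for more inhibition of growth at the one concentration tested (at 33%). Compound 1 `Cc1cc(=O)c2c(O)cc(O)c([C@H]3CCN(C)C[C@H]3OC(=O)c3ccco3)c2o1` gives 22% and compound 2 `Cc1cc(=O)c2c(O)c(CN3CCN(C(=O)OC(C)(C)C)CC3)c(O)c([C@H]3CCN(C)C[C@H]3O)c2o1` gives 13%. Both of these compounds lie beyond the scatter from compound 3. Compound 4 `Cc1cc(=O)c2c(O)c(CN3CCCC3C(=O)O)c(O)c([C@H]3CCN(C)C[C@H]3O)c2o1` has carboxy in place of hydroxymethyl on a saturated ring carbon, a change from 2-(hydroxymethyl)pyrrolidin-1-yl to 2-carboxypyrrolidin-1-yl carboxy in place of hydroxymethyl on a saturated ring carbon and has no number yet. Within the data shown here, no measured pair isolates a single change, so this forecast has no direct precedent. Only a small fall is expected: the estimated a number 10 percentage points lower from compound 3 to compound 4 (within the scatter) in this assay is about the size of the scatter. The expected value for compound 4 is 23% (range 8% to 38%)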

Compound 4, percent growth inhibition at one concentration: 16%
The estimate for compound 4 lay 7 percentage points above the measured number; low and high end bracket the measured number.
By their numbers in this assay, from the lowest: compounds 2, 4 and 1 (each within the scatter of the next); then compound 3.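

In this assay, among these compounds, carboxy in place of hydroxymethyl on a saturated ring carbon, next to the ring nitrogen, gives a number 17 percentage points lower from compound 3 to compound 4 (beyond the scatter) as the first step that isolates one change. The group at this position therefore bears on growth inhibition at the one concentration tested, and hydroxymethyl cannot be exchanged for carboxy without loss. Nothing measured here accounts for the step. Open, from the compounds shown here alone, is how a methyl ester, a primary amide or a longer hydroxyethyl chain at this position would compare with hydroxymethyl and carboxy.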